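The source may hold more compounds than are shown below. What is called first, only, known or untested is meant among the compounds shown, and "the series" means these compounds.

Of the compounds shown here, three have been measured in an assay on isolated protein for inhibition of Polyunsaturated fatty acid 5-lipoxygenase (Homo sapiens); a lower number here means a stronger inhibitor, a higher number a weaker inhibitor: compound 1 `Cc1cccc(N2CCCC(=O)N2)c1` gives 3400 nM; compound 2 `O=C1CCCN(c2cccc(Cl)c2)N1` gives 2500 nM; compound 3 `Cc1cccc(N2CCC(=O)N2)c1` gives 1300 nM.

Compound 2 differs from compound 1 by chloro in place of methyl on an aromatic carbon, and that change made a 1.4-fold lower number from compound 1 to compound 2 (0.13 log units; within the scatter). Compound 3 has a smaller core; how its core differs from that of compound 1 is not broken down here. Compound 4 `O=C1CCN(c2cccc(Cl)c2)N1` is not yet measured and differs from compound 3 by chloro in place of methyl on an aromatic carbon. This is the same kind of change, though the surroundings differ: in the first pair the place is meta to a group of 7 heavy atoms, here meta to a group of 6 heavy atoms. Compound 4 is expected to give 950 nM, between 450 nM and 2000 nM. The expected step of a 1.4-fold lower number from compound 3 to compound 4 (0.14 log units; within the scatter) is small because a 1.4-fold lower number from compound 1 to compound 2 (0.13 log units; within the scatter) was small, and the two cores are not the same.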

Compound 4, half-maximal inhibitory concentration: 730 nM
The estimate for compound 4 lay 1.3-fold (0.11 log units) above the measured number; the measured number falls inside the stated range.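

The swap of methyl for chloro gave a 1.8-fold lower number from compound 3 to compound 4 (0.25 log units; within the scatter), and in this assay its size matches that of the same swap on the other core: the same change on two cores in this assay, a 1.4-fold lower number (0.13 log units; within the scatter) from compound 1 to compound 2 and a 1.8-fold lower number (0.25 log units; within the scatter) from compound 3 to compound 4, 1.3-fold (0.12 log units) apart, within the scatter of two such steps. Within these two pairs, then, the change carries from one core to the other without a detectable difference in its size. Each step lies within the scatter, however, so neither pair separates chloro from methyl, and two cores cannot speak for other cores in the series.

The compounds shown carry only methyl or chloro at this place on the aromatic ring. From the compounds shown here alone, whether a methoxy group, a nitrile or an amine there would shift the number beyond the scatter remains open.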